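A few compounds are considered here, and "the series" means these few. Any claim that something is new, unique, unknown or untested is made for them only; others in the source may bear on it.

Compound 1, `COCCOC(=O)Nc1cc2nc(C3CCCCC3)[nH]c2cc1N1CCCC1`: > 100 ug/mL
Compound 2, `O=C(NCc1ccccc1)Nc1cc2nc(C3CCCCC3)[nH]c2cc1N1CCCC1`: > 100 ug/mL
Compound 3, `CCCN(CCC)c1cc2[nH]c(C3CCCCC3)nc2cc1NC(=O)c1ccccc1`: > 100 ug/mL

All three measured compounds were tested in an ADME assay on Vero cells (Chlorocebus sabaeus) for cytotoxicity, read by resazurin assay, with a stated time of 3 days (on this read-out lower numbers stand for stronger inhibition and higher numbers for weaker inhibition), and none of them gave a number. Compound 3 stands only at a limit of the assay, > 100 ug/mL, and so the numbers shown do not place it relative to the other two. The same holds for the other two compounds, which sit at the limit of > 100 ug/mL in this assay, at which 3 of the 3 values shown sit. Within the data shown here, the one step between measured compounds that differ in a single place, a step that the two limits leave unreadable from compound 1 to compound 2, is therefore unreadable: the benzylamino in place of 2-methoxyethoxy on the carbonyl carbon left both compounds at the limit.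

Compound 4, `O=C(Nc1cc2nc(C3CCCCC3)[nH]c2cc1N1CCCC1)c1ccccc1`, differs from compound 3 in one place: pyrrolidin-1-yl in place of dipropylamino on an aromatic carbon. Among the measured compounds shown here, no measured step speaks to this change directly, and the only measured step in this assay gives no size. Everything measured so far sits at the limit, so the expectation for compound 4 is that it, too, shows no cytotoxicity within the tested range, with a step that the limit leaves unreadable from compound 3 to compound 4 from compound 3 that is estimated to stay within the scatter. Compound 4 is thus expected to give about 120 ug/mL in this assay, with a range of 50 ug/mL to 300 ug/mL.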

Compound 4, half-maximal inhibitory concentration: > 100 ug/mL
Compound 4 ended at the assay's limit; the forecaster's own chance of this, stated with the estimate: 80%; the middle value lies beyond the limit too.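

In this assay compound 4 gives > 100 ug/mL, a limit and not a number, so no new step can be read between it and compound 1, compound 2 or compound 3. The compounds shown leave open whether any of these changes alters the read-out, and at what concentration any of them would register: the limit of > 100 ug/mL in this assay, at which 4 of the 4 values shown sit.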